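Heteroaryl swap on the amide of compound 2

The source may report more compounds than this note shows. Statements on the series, on what has been measured and on what is new or still open speak of the compounds shown alone.

Measured compounds:
compound 1 `Cc1ccc2[nH]c(C(=O)N[C@H]3CCN(S(=O)(=O)c4ccccc4Cl)C[C@@H]3C(=O)N[C@H]3CCCN(C)C3)cc2c1` — 66 uL/min
compound 2 `Cc1csc(C(=O)N[C@H]2CN(S(=O)(=O)c3ccccc3)C[C@@H]2C(=O)N[C@H]2CCCNC2)n1` — < 1 uL/min

In an ADME assay on cells (Hepatocyte, Rattus norvegicus) for metabolic stability (on this read-out higher numbers stand for fast clearance and lower numbers for slow clearance), compound 1 gives 66 uL/min. Compound 2 is reported only as a limit, < 1 uL/min; it sits at the limit of < 1 uL/min in this assay, at which 1 of the 2 values shown sits, the slow end of the two values shown. Compound 3 `O=C(N[C@H]1CN(S(=O)(=O)c2ccccc2)C[C@@H]1C(=O)N[C@H]1CCCNC1)c1cn(C2CC2)cn1` has not been measured in this assay. It differs from compound 2 by 1-cyclopropyl-1H-imidazol-4-yl in place of 4-methyl-1,3-thiazol-2-yl on a carbonyl carbon. Among the compounds with values here, with no step between measured compounds to go by, a small rise in this assay is expected, an at least 3.0-fold higher number from compound 2 to compound 3 (0.47 log units; beyond the scatter), likely within the scatter. Compound 3 is estimated at 3 uL/min, between 0.5 uL/min and 20 uL/min.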

Compound 3, intrinsic clearance in a liver preparation (reported as CLH), per the amount of preparation that the assay uses: < 1 uL/min
Compound 3: a limit, no number (the forecaster's own chance of this, stated with the estimate: 40%); middle value at least 3.0-fold (0.47 log units) away from the limit.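

Compound 2 and compound 3 are both reported only as limits, so no step can be read between them: the limit of < 1 uL/min in this assay, at which 2 of the 3 values shown sit.

From the compounds shown here alone, whether 1-cyclopropyl-1H-imidazol-4-yl in place of 4-methyl-1,3-thiazol-2-yl changes clearance at all remains open.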